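A few compounds are considered here, and "the series" means these few. Any claim that something is new, unique, unknown or untested is made for them only; others in the source may bear on it.

Working notes on the series.

The three measured compounds share one core and differ only in the group on the phenyl ring. Compound 1 `O=C1CSC(c2cccc(O)c2)N1CCN1CCCCC1`, compound 2 `O=C1CSC(c2ccc(O)cc2)N1CCN1CCCCC1` and compound 3 `COc1ccccc1C1SCC(=O)N1CCN1CCCCC1` have all been run in an ADME assay on Vero cells (Chlorocebus sabaeus) for cytotoxicity, read by neutral red uptake, tested at 1575 ug/mL; on this read-out higher numbers stand for a weaker effect at the one concentration tested and lower numbers for a stronger effect. In this assay compound 1 gives 13%, compound 2 gives 12% and compound 3 gives 17%. The gap from compound 3 to compound 1 and the gap from compound 3 to compound 2 both stay within the scatter, so the three numbers sit together. Among the compounds with values here, the only one-place step among them, a number 1 percentage points lower from compound 1 to compound 2 (within the scatter), is also within the scatter.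

Compound 4 `O=C1CSC(c2ccccc2[N+](=O)[O-])N1CCN1CCCCC1` is the next one to be measured in this assay. It differs from compound 3 by nitro in place of methoxy on an aromatic carbon. Within the data shown here, no measured step touches the methoxy or the nitro; the step from compound 1 to compound 2 concerns a hydroxy on the ring and was within the scatter. There is therefore no basis in the numbers for expecting a step beyond the scatter.

The expected step of no change at the digits printed from compound 3 to compound 4 (within the scatter) is taken as flat. For compound 4 the expected value in this assay is 17%, with a range from 7% to 32%.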

Compound 4, a percentage reported as activity, at one concentration (the size of the read-out at that concentration, not a potency): 24%
Compound 4: middle estimate off by 7 percentage points, on the low side; measured number inside the range.
By their numbers in this assay, from the lowest: compounds 2, 1, 3 and 4 (each within the scatter of the next, the first and the last beyond it).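

In this assay, within the data shown here, nitro in place of methoxy on an aromatic carbon, ortho to a large group, gives a number 7 percentage points higher from compound 3 to compound 4 (within the scatter) and so adds a first reading at this position. Among these compounds, the only earlier one-place step concerned a hydroxy on the ring, so this is the first sign that the group at this place can be exchanged, here for one carrying a double bond outside aromatic rings, without the read-out leaving the scatter. Nothing at hand speaks to what lies behind the size of this step.

Still open, going by these compounds, is whether this flat reading holds for groups of another kind at the same aromatic carbon, such as an amine, a carboxylic acid or a longer chain like butoxy, any of which could yet give a step beyond the scatter in this assay on this core. Also open, on these data alone, is whether nitro and methoxy would read the same way elsewhere on the ring, since this single pair speaks only for the place ortho to a large group.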